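Adding a Chloro to Compound 3: An Estimate

This account rests on a few compounds, and the source may have more. Where it says the series, first, only, none or still open, it means among the compounds named here.

Of the compounds shown here, three sharing one core have been tested in a functional assay on DLA cells (Mus musculus) for cytotoxicity, read by MTT assay, with a stated time of 48 h; a higher number here means a weaker inhibitor, a lower number a stronger inhibitor. Compound 1 `COc1ccc(C(=O)c2cc(C)ccc2OCC(=O)NNC(=O)c2cc3ccccc3oc2=O)cc1` gives 42000 nM, compound 2 `Cc1ccc(OCC(=O)NNC(=O)c2cc3ccccc3oc2=O)c(C(=O)c2cccc(Cl)c2)c1` gives 65500 nM, and compound 3 `Cc1ccc(OCC(=O)NNC(=O)c2cc3ccccc3oc2=O)c(C(=O)c2ccccc2)c1` gives 86400 nM. Compound 3 has the highest of the three numbers: the step of a 1.3-fold higher number from compound 2 to compound 3 (0.12 log units; within the scatter) is within the scatter, while the step of a 2.1-fold higher number from compound 1 to compound 3 (0.31 log units; beyond the scatter) is modest but beyond it, so compound 3 is a slightly weaker inhibitor than compound 1 and not distinguishable from compound 2.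

Compound 4 `Cc1ccc(OCC(=O)NNC(=O)c2cc3ccccc3oc2=O)c(C(=O)c2ccccc2Cl)c1` differs from compound 3 in one place: chloro in place of hydrogen on an aromatic carbon. Among the measured compounds shown here, only one measured step speaks to such a change. The step of a 1.3-fold higher number from compound 2 to compound 3 (0.12 log units; within the scatter) removed a chloro from a carbon of the same ring, and it stayed within the scatter. For the measured compounds named here, that step is the whole basis; no measured pair tells of a chloro at the place where it enters in compound 4. A step of similar size in the opposite direction is therefore expected, namely a 1.2-fold lower number from compound 3 to compound 4 (0.09 log units; within the scatter), which lies within the scatter. Compound 4 is thus estimated at 70000 nM in this assay, with a range from 30000 nM to 160000 nM.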

Compound 4, half-maximal inhibitory concentration: 53800 nM
Compound 4: the middle estimate sits 1.3-fold (0.11 log units) above what was measured; measured number inside the range.
By their numbers in this assay, from the lowest: compounds 1, 4, 2 and 3 (each within the scatter of the next, the first and the last beyond it).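

Chloro at this place, on an aromatic carbon ortho to a large group, now has a direct reading in this assay, and the change from phenyl to 2-chlorophenyl stays within the scatter (a 1.6-fold lower number from compound 3 to compound 4 (0.21 log units; within the scatter)). Where the chloro sits on the ring also makes no difference that this assay can resolve, since 2-chlorophenyl and 3-chlorophenyl cannot be told apart (a 1.2-fold lower number from compound 2 to compound 4 (0.09 log units; within the scatter)). Among the compounds shown here, the same holds for 2-chlorophenyl against 4-methoxyphenyl (a 1.3-fold higher number from compound 1 to compound 4 (0.11 log units; within the scatter)), so compound 4 adds no new gap beyond the scatter, and compound 1 and compound 3 remain the only pair printed as lying beyond it.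

Nothing measured here offers an explanation for these small differences. From the compounds shown here alone, it also remains open whether a quite different group on this aromatic carbon, such as an amine, a carboxylic acid or a longer chain, would shift the number beyond the scatter, or whether the ring tolerates such groups as quietly as it tolerates chloro.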